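Solubility of a quinoline ether amide series, compound 3 to 4

The source may report more compounds than this note shows. Statements on the series, on what has been measured and on what is new or still open speak of the compounds shown alone.

Measured so far:
- compound 1 `Cc1cc(C)cc(NC(=O)COc2cc(C)nc3ccc(F)cc23)c1`: 28000 nM
- compound 2 `COc1ccc2nc(C)cc(OC3CCN(c4ccccc4)C3=O)c2c1`: 215000 nM
- compound 3 `COc1ccc2nc(C)cc(OCC(=O)NCc3cc(C)cc(C)c3)c2c1`: 92000 nM

In a physicochemical assay for solubility, in phosphate buffer, measured as kinetic solubility, with a stated time of 1 h, at pH 7.4 (on this read-out lower numbers stand for lower solubility and higher numbers for higher solubility), compound 3 stands second highest of the three numbers. Its nearest neighbour is compound 2, which gives 215000 nM, a gap beyond the scatter, and the furthest is compound 1, which gives 28000 nM, also beyond the scatter.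

The next compound, compound 4 `COc1ccc2nc(C)cc(OCC(=O)Nc3ccc(F)cc3)c2c1`, is not yet measured. It differs from compound 3 in one place: 4-fluorophenyl in place of 3,5-dimethylbenzyl on an amide-type nitrogen

For the measured compounds named here, no step between two measured compounds shows this change on its own, so the expectation rests on the spread of the three numbers. Compound 1, the other compound that carries an aromatic ring directly on the amide-type nitrogen, sits lowest, and the entering group is the smaller of the two. A modest downward step in this assay is expected, close to the scatter, as a 1.5-fold lower number from compound 3 to compound 4 (0.19 log units; within the scatter). Compound 4 is therefore estimated at 60000 nM, with a range from 20000 nM to 180000 nM.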

Compound 4, solubility: 104000 nM
Compound 4: middle estimate off by 1.7-fold (0.24 log units), on the low side; low and high end bracket the measured number.
By their numbers in this assay, from the lowest: compound 1; then compounds 3 and 4 (each within the scatter of the next); then compound 2.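

For the compounds shown here, this is the first step that isolates the group on the amide-type nitrogen, and in this assay the change to 4-fluorophenyl from 3,5-dimethylbenzyl gives a 1.1-fold higher number from compound 3 to compound 4 (0.05 log units; within the scatter) on the shared core. The entering group has fewer heavy atoms and adds a fluorine, yet on this core the read-out does not separate the two groups, so this single change leaves the number within the usual scatter of repeated measurements. Nothing among the data offered here accounts for why the two groups read alike.

Going by these compounds, whether an amine or a carboxylic acid in place of 4-fluorophenyl on the amide-type nitrogen would read the same remains open, as does a longer chain there. The compounds shown also do not tell whether this same swap would stay within the scatter on the core of compound 1.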